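Halogen to methoxy swap in the shared-core series

The source may hold more compounds than are shown below. What is called first, only, known or untested is meant among the compounds shown, and "the series" means these compounds.

Measured so far:
- compound 1 `O=C1CSC(c2cccc(Cl)c2)N1CCN1CCCCC1`: 100%
- compound 2 `O=C1CSC(c2cccc(F)c2)N1CCN1CCCCC1`: 100%

In an ADME assay on Vero cells (Chlorocebus sabaeus) for cytotoxicity, read by neutral red uptake, tested at 25 ug/mL (on this read-out higher numbers stand for a weaker effect at the one concentration tested and lower numbers for a stronger effect), compound 1 gives 100% and compound 2 gives 100%. The one measured step, no change at the digits printed from compound 1 to compound 2 (within the scatter), leaves compound 2 level with compound 1 at the digits shown. Compound 3 `COc1cccc(C2SCC(=O)N2CCN2CCCCC2)c1` differs from compound 2 by methoxy in place of fluoro on an aromatic carbon. Within the data shown here, no measured step covers a methoxy, so the expectation rests only on the absence of movement in no change at the digits printed from compound 1 to compound 2 (within the scatter). The step of a number 4 percentage points lower from compound 2 to compound 3 (within the scatter) is therefore expected to stay within the scatter. For compound 3 the estimate is 96%, with a range from 78% to 100%.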

Compound 3, a percentage reported as activity, at one concentration (the size of the read-out at that concentration, not a potency): 97%
For compound 3 the middle estimate is 1 percentage points below the measured one, within the range that was stated.
By their numbers in this assay, from the lowest: compounds 3, 1 and 2 (each within the scatter of the next).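

In this assay methoxy in place of fluoro on an aromatic carbon gives a number 3 percentage points lower from compound 2 to compound 3 (within the scatter) and methoxy in place of chloro gives a number 3 percentage points lower from compound 1 to compound 3 (within the scatter) at the same place. This position, meta to a large group, therefore accepts a non-halogen group bringing a hydrogen-bond acceptor without a step beyond the scatter, which the two halogens alone could not show. No available evidence bears on this result. As far as these compounds go, whether an amine or a carboxylic acid at this place would give a step beyond the scatter remains open, as does the effect of a longer chain.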